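The source may report more compounds than this note shows. Statements on the series, on what has been measured and on what is new or still open speak of the compounds shown alone.

Compound 1 `COc1c(Br)cc(Br)cc1C(=O)Nc1ccc(Sc2nc3ccccc3s2)c(Cl)c1` is the reference point of the series. In an assay on isolated protein for inhibition of thiosulfate sulfurtransferase (Homo sapiens), with a stated time of 60 min, in the absence of a further agent (a higher number here means a weaker inhibitor, a lower number a stronger inhibitor), compound 1 gives > 100000 nM, which is a limit of the assay and not a number. Compound 2 `COc1c(Br)cc(Br)cc1C(=O)Nc1cccc(Cl)c1` in this assay gives > 100000 nM, again a limit. Compound 3 `COc1c(Br)cc(Br)cc1C(=O)Nc1ccc(Sc2nc3ccccc3s2)cc1` in this assay gives > 100000 nM, also a limit. Hence a step that the two limits leave unreadable from compound 1 to compound 2 and a step that the two limits leave unreadable from compound 1 to compound 3 have no readable size, as shown by the limit of > 100000 nM in this assay, at which 3 of the 3 values shown sit. The change to compound 4 `O=C(Nc1ccc(Sc2nc3ccccc3s2)c(Cl)c1)c1cc(Br)ccc1O` is a group of 8 heavy atoms (6 carbon, 1 oxygen, 1 bromine; one six-membered aromatic ring of carbon only) in place of a group of 10 heavy atoms (7 carbon, 1 oxygen, 2 bromine; one six-membered aromatic ring of carbon only), on a carbonyl carbon, on a carbonyl carbon whose other neighbour is an amide-type nitrogen. Neither measured step touches this part of the molecule, and both are unreadable. The step from compound 1 to compound 4 is therefore expected as a number no higher from compound 1 to compound 4 (the limit leaves the size open). Compound 4 is estimated at 100000 nM in this assay, within 30000 nM to 300000 nM.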

Compound 4, half-maximal inhibitory concentration: > 100000 nM
Compound 4 ended at the assay's limit (the forecaster's own chance of this, stated with the estimate: 80%); the middle value lies on the limit itself.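

The step between compound 1 and compound 4 cannot be read, because both values are limits of the assay and not numbers: the limit of > 100000 nM in this assay, at which 4 of the 4 values shown sit.

The compounds shown leave open whether any change to the core of compound 1 gives a readable value in this assay.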